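Methoxy to ethoxy: from compound 1 to compound 4

The compounds below may be only part of what the source reports. "The series", "measured", "known", "first", "only" and "open" are said of these compounds alone.

Measured so far in a functional assay on PC-3 cells (Homo sapiens) for inhibition, read by sulforhodamine B assay, with a stated time of 48 h, tested at 50 uM; a higher number here means more inhibition of growth at the concentration tested, a lower number less inhibition of growth:
- compound 1 `COc1ccc([C@@H]2CC(=O)c3cc(CC=C(C)C)c(OC)cc3O2)cc1` gives 58%
- compound 2 `COc1ccc([C@@H]2C/C(=N/OCc3cn(-c4ccc(C#N)cc4)nn3)c3cc(CC=C(C)C)c(OC)cc3O2)cc1` gives 50%
- compound 3 `COc1ccc([C@@H]2C/C(=N/O)c3cc(CC=C(C)C)c(OC)cc3O2)cc1` gives 45%

Compound 1 holds the highest of these three numbers, but its standing is only partly secure. Its gap to compound 2 lies within the scatter of repeated measurements, while its gap to compound 3 lies beyond that scatter.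

The next compound to be tested is compound 4 `CCOc1ccc([C@@H]2CC(=O)c3cc(CC=C(C)C)c(OC)cc3O2)cc1`, which keeps the core of compound 1 and changes one group, 4-methoxyphenyl to 4-ethoxyphenyl. The counted difference is methyl in place of hydrogen on a saturated chain carbon bound to an oxygen on an aromatic ring.

Among the measured compounds shown here, no two measured compounds differ in one place only, so the data offer no direct precedent for this change. The expectation in this assay therefore starts from compound 1 at 58% and assumes no step beyond the scatter, in either direction. The estimated a number 3 percentage points lower from compound 1 to compound 4 (within the scatter) is small, and the direction of so small a step is not secure. For compound 4 the expected value is 55% (estimated range 42% to 68%).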

Compound 4, percent growth inhibition at one concentration: 60%
Compound 4: middle estimate off by 5 percentage points, on the low side; measured number inside the range.
By their numbers in this assay, from the lowest: compounds 3, 2, 1 and 4 (each within the scatter of the next, the first and the last beyond it).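

Among the compounds shown here, the step of a number 2 percentage points higher from compound 1 to compound 4 (within the scatter) in this assay is the first direct reading of this position, as no earlier pair of compounds differed in one place only. It shows that going from 4-methoxyphenyl to 4-ethoxyphenyl, which puts methyl in place of hydrogen on a saturated chain carbon bound to an oxygen on an aromatic ring, keeps growth inhibition on the core of compound 1 within the scatter of repeated measurements. This position therefore accepts that one added methyl without a step beyond the scatter, although this single pair says nothing about the same change on the oxime-bearing structures of compound 2 and compound 3.

On these data alone, whether a longer chain such as propoxy or butoxy, a benzyloxy group, a free hydroxyl, or an amine or a carboxylic acid carried on the chain would step beyond the scatter at this place remains open. No measured property accompanies this result that could account for it.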